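Sulfanyl in Place of Cyanoamino on the Shared Chain

This account rests on a few compounds, and the source may have more. Where it says the series, first, only, none or still open, it means among the compounds named here.

In a functional assay on the whole organism with Rattus norvegicus as the target (on this read-out higher numbers stand for an effect only at larger amounts of compound and lower numbers for an effect already at smaller amounts), compound 3 `C/N=C(\NC#N)NCCCCn1nc(-c2ccccc2)ccc1=O` gives 38.5 mg/kg and stands at the low end of the two numbers shown; compound 2 `CC/N=C(/NC#N)NCCCCCn1nc(-c2ccccc2)ccc1=O`, at 60.3 mg/kg, lies within the scatter of it. For compound 1 `C/N=C(/NC#N)NCCCCCCn1nc(-c2ccccc2)ccc1=O` this assay reports only a limit, > 100 mg/kg. For the measured compounds named here, the one measured step, an at least 1.6-fold lower number from compound 1 to compound 2 (0.21 log units; that floor lies within the scatter), is bounded because of the limit of > 100 mg/kg in this assay, at which 1 of the 3 values shown sits. Compound 4 `C/N=C(\S)NCCCCn1nc(-c2ccccc2)ccc1=O` differs from compound 3 by sulfanyl in place of cyanoamino on a carbon with a double bond to nitrogen. Going by the values given here, no measured step exchanges cyanoamino for sulfanyl, and the step from compound 1 to compound 2 concerns a different place; it offers no direction. Compound 4 is therefore expected near compound 3, at 40 mg/kg, between 15 mg/kg and 100 mg/kg. The step expected is a 1.0-fold higher number from compound 3 to compound 4 (0.02 log units; within the scatter), none beyond the scatter.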

Compound 4, dose for half-maximal effect: 17.3 mg/kg
Compound 4: the middle estimate sits 2.3-fold (0.36 log units) above what was measured; measured number inside the range.
By their numbers in this assay, from the lowest: compound 4; then compounds 3 and 2 (each within the scatter of the next). At a limit, above all of these: compound 1.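

At the carbon with a double bond to nitrogen, the substituent matters in this assay: sulfanyl in place of cyanoamino gives a 2.2-fold lower number from compound 3 to compound 4 (0.35 log units; beyond the scatter) and is the only step shown that is read as beyond the scatter. The triple bond of cyanoamino is therefore not needed for an effect in this whole-animal read-out. No measurement shown explains the step.

The compounds shown leave open how an amine or a carboxylic acid would behave on this carbon. They also leave open whether the same exchange gives a similar step on a longer chain.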